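Hydroxymethyl in place of methyl on the shared core

The source may report more compounds than this note shows. Statements on the series, on what has been measured and on what is new or still open speak of the compounds shown alone.

Of the compounds shown here, three sharing one core have been measured in a functional assay on CHO-K1 cells for antagonist activity at prostaglandin E2 receptor EP1 subtype (Homo sapiens), read by FLIPR; a lower number here means a stronger inhibitor, a higher number a weaker inhibitor. Compound 1 `CCCCc1cc(C(=O)O)nn1Cc1cc(Br)ccc1OCc1ccccc1` gives 977 nM. Compound 2 `O=C(O)c1nn(Cc2cc(Br)ccc2OCc2ccccc2)cc1F` gives 692 nM. Compound 3 `Cc1cn(Cc2cc(Br)ccc2OCc2ccccc2)nc1C(=O)O` gives 1350 nM. Compound 3 has the highest of the three numbers, but its gap to compound 1 and its gap to compound 2 both lie within the scatter, so none of the three can be set apart from the others. Among the measured compounds shown here, the only single-change step among them, a 2.0-fold higher number from compound 2 to compound 3 (0.29 log units; within the scatter), is also within the scatter, and it concerns the exchange of fluoro for methyl, not the change considered here.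

Compound 4 `O=C(O)c1nn(Cc2cc(Br)ccc2OCc2ccccc2)cc1CO` differs from compound 3 by hydroxy in place of hydrogen on a saturated chain carbon bound to an aromatic carbon. For the measured compounds named here, no measured pair reports this change, so nothing in the numbers speaks for a shift in either direction. Going by the values given here, since the three measured values sit within the scatter of each other and the one counted step was small, compound 4 is expected to stay close to compound 3, with a 1.1-fold lower number from compound 3 to compound 4 (0.05 log units; within the scatter) as the anticipated step. The estimate for compound 4 in this assay is 1200 nM, with a range from 450 nM to 3200 nM.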

Compound 4, inhibition constant: < 2000 nM
Compound 4 gave a limit, no number (the forecaster's own chance of this, stated with the estimate: 5%); the middle value is on the limit's open side.
By their numbers in this assay, from the lowest: compounds 2, 1 and 3 (each within the scatter of the next).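

In this assay compound 4 gave < 2000 nM as a limit and not as a number. The steps to compound 4 from compound 3 and from compound 2 therefore cannot be read. The compounds shown leave open whether hydroxymethyl in place of methyl on the shared core changes the number in this assay at all, and in which direction.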